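From 4-(trifluoromethyl)phenyl to 2-chlorophenyl on a shared core

The source may hold more compounds than are shown below. What is called first, only, known or untested is meant among the compounds shown, and "the series" means these compounds.

In a functional assay on MDA-MB-231 cells (Homo sapiens) for antiproliferative activity, read by MTT assay, with a stated time of 72 h (on this read-out lower numbers stand for stronger inhibition and higher numbers for weaker inhibition), compound 1 (`CC1=CC[C@H]2[C@H](CC[C@]2(C)O)C(C)(C)[C@@H]1CC[C@H]1[C@]2(C)CC[C@H](OC(=O)c3ccc(C)cc3)C(C)(C)O[C@H]2CC[C@@]1(C)O`) gives 33400 nM and compound 2 (`CC1=CC[C@H]2[C@H](CC[C@]2(C)O)C(C)(C)[C@@H]1CC[C@H]1[C@]2(C)CC[C@H](OC(=O)NS(=O)(=O)c3ccc(C)cc3)C(C)(C)O[C@H]2CC[C@@]1(C)O`) gives 47100 nM while compound 3 (`CC1=CC[C@H]2[C@H](CC[C@]2(C)O)C(C)(C)[C@@H]1CC[C@H]1[C@]2(C)CC[C@H](OC(=O)c3ccc(C(F)(F)F)cc3)C(C)(C)O[C@H]2CC[C@@]1(C)O`) gives 19500 nM on the same scale. Compound 3 cannot be separated from compound 1, as the measured step shows (a 1.7-fold lower number from compound 1 to compound 3 (0.23 log units; within the scatter)). Its margin over compound 2 is beyond the scatter but modest (a 2.4-fold lower number from compound 2 to compound 3 (0.38 log units; beyond the scatter)). The next compound, compound 4 (`CC1=CC[C@H]2[C@H](CC[C@]2(C)O)C(C)(C)[C@@H]1CC[C@H]1[C@]2(C)CC[C@H](OC(=O)c3ccccc3Cl)C(C)(C)O[C@H]2CC[C@@]1(C)O`), carries 2-chlorophenyl in place of 4-(trifluoromethyl)phenyl on a carbonyl carbon. Within the data shown here, no measured compound carries 2-chlorophenyl, so there is no direct precedent for this exchange. The closest evidence is the step that replaced methyl with trifluoromethyl on an aromatic carbon (a 1.7-fold lower number from compound 1 to compound 3 (0.23 log units; within the scatter)), which stayed within the scatter. Even the larger change from compound 1 to compound 2 moved the number little (a 1.4-fold higher number from compound 1 to compound 2 (0.15 log units; within the scatter)). Changes at this carbonyl carbon have so far shifted the read-out only slightly, so no step beyond the scatter is expected, and no direction can be firmly predicted. The expected step is small (a 1.4-fold higher number from compound 3 to compound 4 (0.14 log units; within the scatter)). In this assay compound 4 is estimated at 27000 nM with an expected range from 12000 nM to 60000 nM around that middle.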

Compound 4, half-maximal inhibitory concentration: 24300 nM
For compound 4 the middle estimate is 1.1-fold (0.05 log units) above the measured one; low and high end bracket the measured number.
By their numbers in this assay, from the lowest: compounds 3, 4, 1 and 2 (each within the scatter of the next, the first and the last beyond it).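

In this assay, among these compounds, replacing 4-(trifluoromethyl)phenyl with 2-chlorophenyl on a carbonyl carbon, a change that removes the only fluorinated group and brings in the only chlorinated one, gave a step within the scatter (a 1.2-fold higher number from compound 3 to compound 4 (0.10 log units; within the scatter)). The other two new steps also stayed within the scatter (a 1.4-fold lower number from compound 1 to compound 4 (0.14 log units; within the scatter)) and (a 1.9-fold lower number from compound 2 to compound 4 (0.29 log units; within the scatter)), so the newest compound cannot be separated from any of the three earlier ones, and the aromatic groups attached directly to this carbonyl carbon in compounds 1, 3 and 4 all remain within the scatter of one another, with the step to compound 3 from the sulfonyl-bearing compound 2 still the only one beyond it (a 2.4-fold lower number from compound 2 to compound 3 (0.38 log units; beyond the scatter)). No measurement shown here accounts for how little these exchanges moved the number.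

The compounds shown leave open whether any group on this carbonyl carbon can move the number well beyond the scatter, for instance a ring carrying an amine or a carboxylic acid, or a longer alkyl chain in place of the ring. They also leave open whether changes elsewhere on the shared core would matter more than changes at this position.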